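A ring swap on a carbonyl carbon: cytotoxicity outlook

The source may hold more compounds than are shown below. What is called first, only, known or untested is meant among the compounds shown, and "the series" means these compounds.

Compound 1, `Cc1c(C(=O)N/N=C/c2ccc([N+](=O)[O-])s2)no[n+]1[O-]`: > 400000 nM
Compound 2, `Cc1c(/C=N/NC(=O)c2ccncc2)no[n+]1[O-]`: > 400000 nM
Compound 3, `Cc1c(C(=O)N/N=C/c2ccccc2O)no[n+]1[O-]`: 246000 nM

All three were tested in an ADME assay on J774.1 cells (Mus musculus) for cytotoxicity, read by MTT assay, with a stated time of 48 h; on this read-out higher numbers stand for weaker inhibition and lower numbers for stronger inhibition. For compound 1 the figure is a limit of the assay, not a number. For compound 2 it is likewise a limit, not a measured number. Compound 3 alone gives a number, 246000 nM. Compound 2 therefore sits at the limit of > 400000 nM in this assay, at which 2 of the 3 values shown sit, and cannot be ranked against compound 1 on these figures.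

Compound 4, `Cc1[nH]cnc1C(=O)N/N=C/c1no[n+]([O-])c1C`, differs from compound 2 in one place: 5-methyl-1H-imidazol-4-yl in place of pyridin-4-yl on a carbonyl carbon. Among the compounds with values here, no pair of measured compounds separated by a single change exists here to calibrate this swap. The expected step in this assay is none beyond the scatter, which is what a number no higher from compound 2 to compound 4 (the limit leaves the size open) expresses. Compound 4 is thus estimated at 400000 nM, in the range 200000 nM to 800000 nM, and it is expected most likely to come back only as a limit.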

Compound 4, half-maximal inhibitory concentration: > 400000 nM
Compound 4: no number, only a limit; the forecaster's own chance of this, stated with the estimate: 75%; the middle value sits exactly at the limit.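

Within the data shown here, compound 2 and compound 4 both give only a limit of the assay in this assay, and no step between them can be read. The compounds shown leave open whether 5-methyl-1H-imidazol-4-yl in place of pyridin-4-yl on a carbonyl carbon changes cytotoxicity at all.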